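Swapping an Amide for a Thiourea-Type Group

The source may hold more compounds than are shown below. What is called first, only, known or untested is meant among the compounds shown, and "the series" means these compounds.

Measured so far:
compound 1 `CCCC(=O)NCCC(=O)c1cc(OC)ccc1N` — 7.35%
compound 2 `Nc1ccc(Cl)cc1C(=O)CCNC(=O)C1CC1` — 5.37%

In an assay for inhibition of Nitric oxide synthase, inducible (Homo sapiens), read by scintillation counting, with a stated time of 30 min, tested at 1 mM (on this read-out higher numbers stand for more inhibition at the one concentration tested (going by the name of the read-out) and lower numbers for less inhibition), compound 1 gives 7.35%, the higher of the two numbers shown. In this assay compound 2 gives 5.37%, and the gap between compound 1 and compound 2 lies within the usual scatter, so the two cannot be told apart; both show only slight inhibition at the single concentration tested.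

Compound 3 `CNC(=S)NCCC(=O)c1cc(OC)ccc1N` is not yet measured. It differs from compound 1 in one place: a group of 4 heavy atoms (2 carbon, 1 nitrogen, 1 sulfur; no ring) in place of a group of 5 heavy atoms (4 carbon, 1 oxygen; no ring), on an amine nitrogen. The propylcarbonyl leaves and a sulfur-bearing group with one hydrogen-bond donor enters. For the measured compounds named here, no measured pair shows a change of this kind, so there is nothing to anchor the direction. Given that both measured compounds sit near the bottom of the scale, compound 3 is expected to stay in that region, with the step from compound 1 being a number 0.7 percentage points higher from compound 1 to compound 3 (within the scatter), within the scatter. The estimate for compound 3 is 8%, between 0% and 25%.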

Compound 3, a percentage reported as inhibition, at one concentration (the size of the read-out at that concentration, not a potency): 78.2%
Estimate against measurement, compound 3: 70.2 percentage points below; measured number outside the range, above it.
By their numbers in this assay, from the lowest: compounds 2 and 1 (each within the scatter of the next); then compound 3.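

In this assay, this is the first change in one place among the compounds shown, and it reveals that the group on the amine nitrogen can have a large influence: exchanging the propylcarbonyl for the sulfur-bearing group gives a number 70.9 percentage points higher from compound 1 to compound 3 (beyond the scatter). The shared core is untouched, so this jump goes with the exchanged group alone, and a small change in heavy-atom count can separate slight inhibition from strong inhibition at the single concentration tested. Nothing available here explains the size of this jump.

The compounds shown leave open whether the sulfur itself is needed, which a urea, with oxygen in its place, would test. They also leave open whether an ethyl group in place of the methyl on the terminal nitrogen would keep this inhibition.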